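The compounds below may be only part of what the source reports. "The series", "measured", "known", "first", "only" and "open" are said of these compounds alone.

Compound 2 `CN(C)CCn1cnnc1-c1cc(Oc2ccc(NC(=O)N/N=C/c3cccc(Br)c3)cc2F)ccn1` stands at 970 nM in a functional assay on A549 cells (Homo sapiens) for cytotoxicity, read by MTT assay, with a stated time of 72 h (on this read-out lower numbers stand for stronger inhibition and higher numbers for weaker inhibition), with compound 1 `CN(C)CCn1cnnc1-c1cc(Oc2ccc(NC(=O)N/N=C/c3c(Cl)cccc3Cl)cc2F)ccn1` at 1410 nM, the two numbers within the usual scatter of each other. Going by the values given here, the one step known, a 1.5-fold lower number from compound 1 to compound 2 (0.16 log units; within the scatter), swapped one ring for another on the same carbon. Compound 3 `CN(C)CCn1cnnc1-c1cc(Oc2ccc(NC(=O)N/N=C/c3cc(Br)c(O)c(Br)c3)cc2F)ccn1` carries 3,5-dibromo-4-hydroxyphenyl in place of 3-bromophenyl on a carbon with a double bond to nitrogen. That single step bears only loosely on this change, since it brought no hydroxyl, and it stayed within the scatter. The expected step of a 1.1-fold lower number from compound 2 to compound 3 (0.03 log units; within the scatter) is therefore small, in no clear direction. Compound 3 is estimated at 900 nM, within 300 nM to 2700 nM.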

Compound 3, half-maximal inhibitory concentration: > 100000 nM
Compound 3: no number, only a limit; the forecaster's own chance of this, stated with the estimate: 5%; at least 110-fold (2.04 log units) between middle value and limit.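

At this carbon, the ring cannot be swapped freely: in this assay, 3,5-dibromo-4-hydroxyphenyl in place of 3-bromophenyl gives an at least 100-fold higher number from compound 2 to compound 3 (2.01 log units; beyond the scatter), and in place of 2,6-dichlorophenyl it gives an at least 70-fold higher number from compound 1 to compound 3 (1.85 log units; beyond the scatter). The earlier ring swap, which stayed within the scatter, did not reveal this sensitivity. For compound 3 the figure is a limit, not a number: the limit of > 100000 nM in this assay, at which 1 of the 3 values shown sits.

The compounds shown do not separate the hydroxyl from the second bromine, so which of them matters stays open. Also open, from the compounds shown here alone, is how a plain 4-hydroxyphenyl or an amine on this ring would behave.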